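A few compounds are considered here, and "the series" means these few. Any claim that something is new, unique, unknown or untested is made for them only; others in the source may bear on it.

Measured compounds:
compound 1, `Nc1cc(N)c2nc(-c3ccccc3)c(Oc3ccc(Cl)c(Cl)c3)nc2c1` — < 100000 nM in a functional assay on MOLT-4 cells (Homo sapiens) for inhibition, read by sulforhodamine B assay, with a stated time of 48 h; on this read-out higher numbers stand for weaker inhibition of growth and lower numbers for stronger inhibition of growth
compound 2, `CCOC(=O)[C@H](CCC(=O)O)NC(=O)c1ccc(Sc2nc3cc(N)cc(N)c3nc2-c2ccccc2)cc1` — < 100000 nM in this assay

Compound 1 is known only by a limit. In this assay compound 1 gives < 100000 nM, and that value is a limit of the assay rather than a number. Compound 2 is in the same position: in this assay compound 2 gives < 100000 nM, also a limit. Both values thus sit on the same boundary (the limit of < 100000 nM in this assay, at which 2 of the 2 values shown sit), so nothing shows where either compound stands within the range that the assay can resolve.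

Compound 3, `Nc1cc(N)c2nc(-c3ccccc3)c(Oc3ccc(F)cc3)nc2c1`, has not yet been measured. It differs from compound 1 in one place: 4-fluorophenyl in place of 3,4-dichlorophenyl on an oxygen on an aromatic ring. For the measured compounds named here, no measured step between two compounds shows what such a change does here, so no step beyond the scatter is expected in either direction. With the limit of compound 1 as the only anchor, compound 3 is expected to land near the same boundary, and the step from compound 1 to compound 3 is estimated as a step that the limit leaves unreadable from compound 1 to compound 3. The expected value for compound 3 in this assay is 40000 nM, within a range from 5000 nM to 100000 nM.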

Compound 3, concentration for total growth inhibition: < 100000 nM
Compound 3 ended at the assay's limit; the forecaster's own chance of this, stated with the estimate: 65%; the middle value is on the limit's open side.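

Compound 1 and compound 3 both stand only at a limit of this assay, not at a number, so no step can be read between them: the limit of < 100000 nM in this assay, at which 3 of the 3 values shown sit.

The compounds shown leave open where each one truly stands and whether swapping 3,4-dichlorophenyl for 4-fluorophenyl changes growth inhibition at all.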